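From amino to tert-butyl: will cytotoxicity appear?

This account rests on a few compounds, and the source may have more. Where it says the series, first, only, none or still open, it means among the compounds named here.

Of the compounds shown here, three sharing one core have been tested so far in an ADME assay on HepG2 cells (Homo sapiens) for cytotoxicity, with a stated time of 72 h; on this read-out higher numbers stand for an effect only at larger amounts of compound and lower numbers for an effect already at smaller amounts. Compound 1 (`Cc1cc(NC(=O)Nc2ccccc2OC(F)(F)F)c2ccccc2n1`) gives > 25000 nM, which is a limit of the assay and not a number. Compound 2 (`Cc1cc(NC(=O)Nc2ccccc2N)c2ccccc2n1`) gives > 25000 nM, again only a limit. Compound 3 (`Cc1ccc(NC(=O)Nc2cc(C)nc3ccccc23)cc1`) gives > 25000 nM, also only a limit. Compound 2 therefore has no exact position: it sits with the other two at the limit of > 25000 nM in this assay, at which 3 of the 3 values shown sit.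

Compound 4 (`Cc1cc(NC(=O)Nc2ccccc2C(C)(C)C)c2ccccc2n1`) has not yet been measured. It carries tert-butyl in place of amino on an aromatic carbon, ortho to a large group: tert-butyl in place of amino on an aromatic carbon.

Two measured steps are available. Amino in place of trifluoromethoxy on an aromatic carbon bears most closely on the new change, as it alters the same place, but it is a step that the two limits leave unreadable from compound 1 to compound 2. The change of 4-methylphenyl in place of 2-aminophenyl on an amide-type nitrogen is a step that the two limits leave unreadable from compound 2 to compound 3. Neither step has a readable size, so neither points to a direction, and no step beyond the scatter is expected. The expected change is a step that the limit leaves unreadable from compound 2 to compound 4, and the result may well be only a limit again. For compound 4 the estimated value is 30000 nM, with an expected range from 12000 nM to 60000 nM.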

Compound 4, half-maximal effective concentration: > 25000 nM
Compound 4: a limit, no number; the forecaster's own chance of this, stated with the estimate: 80%; the middle value lies beyond the limit too.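

Compound 4, like compound 1 and compound 2, gives only a limit of the assay and not a number, so neither step to compound 4 can be read: the limit of > 25000 nM in this assay, at which 4 of the 4 values shown sit. The compounds shown leave open at what concentration any of them would show an effect in this assay, and whether exchanging these groups changes that concentration at all.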